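Biaryl amides with a hexanoate tail: cytotoxicity notes

This account rests on a few compounds, and the source may have more. Where it says the series, first, only, none or still open, it means among the compounds named here.

Compound 1 `CC(=O)c1cccc(-c2ccc(C(=O)N(Cc3cccc(OCCCCCC(=O)O)c3)C(C)C)cc2)c1` gives, in an ADME assay on HEK293 cells (Homo sapiens) for cytotoxicity, read by CellTiter-Glo and resazurin assay, with a stated time of 72 h (a lower number here means that less compound is needed, a higher number that more compound is needed for the effect), > 26000 nM, a limit of the assay and not a number.
Compound 2 `CC(C)N(Cc1cccc(OCCCCCC(=O)O)c1)C(=O)c1ccc(-c2ccoc2)cc1` gives in this assay > 26000 nM, again a limit of the assay.
Compound 3 `CCOC(=O)CCCCCOc1cccc(CN(C(=O)c2ccc(-c3ccoc3)cc2)C(C)C)c1` gives in this assay > 26000 nM, likewise a limit of the assay.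

Going by the values given here, compound 3 thus stands at the limit of this assay together with the other two measured members; the limit of > 26000 nM in this assay, at which 3 of the 3 values shown sit, shows that every value so far sits there, so no ordering among compounds 1, 2 and 3 can be read.

The untested member is compound 4 `CCOC(=O)CCCCCOc1cccc(CN(C(=O)c2ccc(-c3cc(OC)ccc3F)cc2)C(C)C)c1`. The change from compound 3 is 2-fluoro-5-methoxyphenyl in place of furan-3-yl on an aromatic carbon.

Among the compounds with values here, no measured step concerns this change directly. From the compounds shown here alone, the two steps available, a step that the two limits leave unreadable from compound 1 to compound 2 and a step that the two limits leave unreadable from compound 2 to compound 3, are both unreadable, each sitting between two limits, so their size is unknown. Within the data shown here, they show only that the exchange of the biaryl substituent in the step from compound 1 to compound 2 and the ethyl ester in the step from compound 2 to compound 3 left the value at the limit.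

Compound 4 is therefore expected, like compound 3, to reach only the limit of this assay, the step of a number no higher from compound 3 to compound 4 (the limit leaves the size open) being expected to stay within the scatter. Compound 4 is estimated at 26000 nM, with a range from 13000 nM to 60000 nM.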

Compound 4, half-maximal effective concentration: > 26000 nM
Compound 4 gave a limit, no number; the forecaster's own chance of this, stated with the estimate: 85%; the middle value lies on the limit itself.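

Between compound 3 and compound 4 no step can be read, since both stand only at a limit in this assay. The series remains without a single number: the limit of > 26000 nM in this assay, at which 4 of the 4 values shown sit.

The compounds shown leave open the actual half-maximal concentration of each of the four compounds, and with it any ordering among them.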